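Replacing the 3,4-dimethoxyphenyl group of compound 1

The compounds below may be only part of what the source reports. "The series", "measured", "known", "first", "only" and "open" are said of these compounds alone.

In a functional assay on A2780 cells (Homo sapiens) for inhibition, read by sulforhodamine B assay (on this read-out higher numbers stand for weaker inhibition of growth and lower numbers for stronger inhibition of growth), compound 1 (`COc1ccc(-c2ccc(-c3ccc(-c4nc5cc(C)ccc5[nH]4)cc3)cc2)cc1OC`) gives 2130 nM and compound 3 (`COc1ccc(-c2ccc(-c3ccc(-c4nc5c(O)cccc5[nH]4)cc3)cc2)cc1OC`) gives 2710 nM, together the high end of the three numbers, while compound 2 (`COc1cc(-c2ccc(-c3ccc(-c4nc5cc(C)ccc5[nH]4)cc3)cc2)cc(OC)c1OC`) gives 190 nM. Compound 4 (`Cc1ccc2[nH]c(-c3ccc(-c4ccc(-c5ccc(C(F)(F)F)cc5)cc4)cc3)nc2c1`) carries 4-(trifluoromethyl)phenyl in place of 3,4-dimethoxyphenyl on an aromatic carbon. Among the measured compounds shown here, the one measured step touching this group is large, an 11-fold lower number from compound 1 to compound 2 (1.05 log units; beyond the scatter), with methoxy in place of hydrogen on an aromatic carbon, which suggests that losing methoxy groups could raise the number. The other step, a 1.3-fold higher number from compound 1 to compound 3 (0.10 log units; within the scatter), lies elsewhere on the molecule. For the measured compounds named here, no measured compound carries trifluoromethyl, so the evidence is indirect. Only a small upward step is expected, a 1.9-fold higher number from compound 1 to compound 4 (0.27 log units; within the scatter). Compound 4 is estimated at 4000 nM, within a range of 1000 nM to 15000 nM.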

Compound 4, concentration for 50% growth inhibition: 12300 nM
Beside the measured number, compound 4's estimate is 3.1-fold (0.49 log units) below it, within the range that was stated.
By their numbers in this assay, from the lowest: compound 2; then compounds 1 and 3 (each within the scatter of the next); then compound 4.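

In this assay, exchanging the whole 3,4-dimethoxyphenyl group for 4-(trifluoromethyl)phenyl gives a 5.8-fold higher number from compound 1 to compound 4 (0.76 log units; beyond the scatter), a step beyond the scatter. The earlier compounds shown here changed only the number of methoxy groups on this ring, whereas this result shows that the number also moves when both oxygens leave and fluorine enters. Nothing measured here accounts for this step.

The compounds shown do not separate the loss of the methoxy groups from the arrival of trifluoromethyl. As far as these compounds go, how an amine or a carboxylic acid on this ring would read also remains open.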